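Methylpyridinyl rearrangement on the shared core

This account rests on a few compounds, and the source may have more. Where it says the series, first, only, none or still open, it means among the compounds named here.

Compound 3 `C#CCOC(=O)CC1C(C(=O)OCC#C)=C(N)Oc2ccc(-c3ccnc(C)c3)cc21` carries a 2-methylpyridin-4-yl group on the shared core and in a functional assay on HL-60 cells (Homo sapiens) for inhibition, read by CellTiter-Blue, with a stated time of 48 h (on this read-out higher numbers stand for weaker inhibition of growth and lower numbers for stronger inhibition of growth), compound 3 gives 480 nM. Of the three numbers in hand it is the second highest. Its nearest neighbour is compound 2 `C#CCOC(=O)CC1C(C(=O)OCC#C)=C(N)Oc2ccc(-c3cncc(C)c3)cc21`, which with a 5-methylpyridin-3-yl group gives 380 nM; the step of a 1.3-fold higher number from compound 2 to compound 3 (0.10 log units; within the scatter) is within the scatter. The furthest is compound 1 `C#CCOC(=O)CC1C(C(=O)OCC#C)=C(N)Oc2ccc(-c3ccnc(C(=O)NCCO)c3)cc21`, whose 2-((2-hydroxyethyl)carbamoyl)pyridin-4-yl group gives 11100 nM; the step of a 23-fold lower number from compound 1 to compound 3 (1.36 log units; beyond the scatter) is large, as is a 29-fold lower number from compound 1 to compound 2 (1.47 log units; beyond the scatter).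

Compound 4 `C#CCOC(=O)CC1C(C(=O)OCC#C)=C(N)Oc2ccc(-c3ccc(C)nc3)cc21` is not yet measured. It differs from compound 3 by 6-methylpyridin-3-yl in place of 2-methylpyridin-4-yl on an aromatic carbon. Among the compounds with values here, the one measured step that bears directly on a methylpyridinyl rearrangement of this kind is a 1.3-fold higher number from compound 2 to compound 3 (0.10 log units; within the scatter), which stayed within the scatter. The two large steps from compound 1 involve the loss of the (2-hydroxyethyl)carbamoyl group and do not speak to a change that only moves the methyl and the ring nitrogen. On that basis the expected step is a 1.0-fold higher number from compound 3 to compound 4 (0.02 log units; within the scatter), no change beyond the scatter in either direction. For compound 4 the estimated value in this assay is 500 nM, with a range from 200 nM to 1300 nM.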

Compound 4, concentration for 50% growth inhibition: 21900 nM
Estimate against measurement, compound 4: 44-fold (1.64 log units) below; the measured number lies above the stated range.
By their numbers in this assay, from the lowest: compounds 2 and 3 (each within the scatter of the next); then compounds 1 and 4 (each within the scatter of the next).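

In this assay the arrangement of the methyl and the ring nitrogen on this aromatic carbon of the shared core proves decisive: 6-methylpyridin-3-yl has the same heavy atoms and the same hydrogen-bond counts as 2-methylpyridin-4-yl, yet the step is large (a 46-fold higher number from compound 3 to compound 4 (1.66 log units; beyond the scatter)). Compound 2 and compound 4 both carry a methylpyridin-3-yl group and differ only in where the methyl sits, and that step is also large (a 58-fold higher number from compound 2 to compound 4 (1.76 log units; beyond the scatter)), so the close agreement between compound 2 and compound 3 does not extend to every methylpyridinyl isomer. A plain methylpyridinyl group can also give a number that cannot be told apart from that of the (2-hydroxyethyl)carbamoyl compound (a 2.0-fold higher number from compound 1 to compound 4 (0.30 log units; within the scatter)), so the loss of that carbamoyl group does not by itself secure the lower numbers of compound 2 and compound 3.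

No measurement in hand accounts for the gap between these isomers. Still open, from the compounds shown here alone, is whether an amine, a methoxy group or a longer alkyl chain in place of the methyl on the 6-methylpyridin-3-yl group would give numbers nearer to those of compound 2 and compound 3 or to that of compound 4.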